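The source may hold more compounds than are shown below. What is called first, only, known or untested is meant among the compounds shown, and "the series" means these compounds.

Compound 3 `COc1ccc(C2CC(c3cc4ccccc4o3)=NN2C(=O)c2ccncc2)c(O)c1` was tested in an ADME assay on Vero cells (Chlorocebus sabaeus) for cytotoxicity, read by MTT assay, with a stated time of 72 h (a higher number here means a weaker inhibitor, a lower number a stronger inhibitor), and in it compound 3 gives > 190000 nM, which is a limit of the assay rather than a number. Compound 1 `O=C(c1ccncc1)N1N=C(c2cc3ccccc3o2)CC1c1ccccc1O` likewise reaches only a limit, giving > 195000 nM in this assay. Compound 2 `O=C(c1ccncc1)N1N=C(c2cc3ccccc3o2)CC1c1cccc([N+](=O)[O-])c1` also gives only a limit in this assay, at > 240000 nM. Compound 4 `O=C(c1ccncc1)N1N=C(c2cc3ccccc3o2)CC1c1ccc(O)cc1` differs from compound 3 by 4-hydroxyphenyl in place of 2-hydroxy-4-methoxyphenyl on a saturated ring carbon. The steps a step that the two limits leave unreadable from compound 1 to compound 3, a step that the two limits leave unreadable from compound 1 to compound 2 and a step that the two limits leave unreadable from compound 2 to compound 3 all run between limits, so their sizes cannot be read. Each value sits at a limit (the limit of > 190000 nM in this assay, at which 1 of the 3 values shown sits, (the limit of > 195000 nM in this assay, at which 1 of the 3 values shown sits), (the limit of > 240000 nM in this assay, at which 1 of the 3 values shown sits)), and no direction of change is readable. Compound 4 is therefore expected to sit at a limit as well, estimated at 200000 nM with a range from 100000 nM to 400000 nM. The step is estimated as a step that the limit leaves unreadable from compound 3 to compound 4, none beyond the scatter.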

Compound 4, half-maximal inhibitory concentration: > 200000 nM
Compound 4 gave a limit, no number; the forecaster's own chance of this, stated with the estimate: 85%; the middle value lies on the limit itself.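

In this assay compound 4 gives > 200000 nM, again a limit and not a number, so its steps to compound 1, compound 2 and compound 3 cannot be read. The compounds shown leave open whether changing the group on the saturated ring carbon alters this value at all.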